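The source may hold more compounds than are shown below. What is called first, only, known or untested is meant among the compounds shown, and "the series" means these compounds.

Measured so far:
- compound 1, `COc1cc(/C=C2\CCC/C(=C\c3cccc(OC)c3OC)C2=O)ccc1O`: 14300 nM
- compound 2, `COc1ccc(/C=C2\CCC/C(=C\c3ccccc3Cl)C2=O)cc1OC`: 21600 nM

In an ADME assay on NHDF cells (Homo sapiens) for cytotoxicity, read by MTT assay, with a stated time of 72 h (a lower number here means a stronger inhibitor, a higher number a weaker inhibitor), compound 2 gives 21600 nM, the higher of the two numbers obtained so far. Compound 1 sits close by, a step within the scatter, so no order between the two can be stated from these numbers.

The next compound in the series is compound 3, `COc1ccc(/C=C2\CCC/C(=C\c3cccc(Cl)c3Cl)C2=O)cc1OC`. Its difference from compound 2 is a single change: chloro in place of hydrogen on an aromatic carbon. Among the compounds with values here, no pair of measured compounds carries this change, so the size of the step is not known from the data in this assay.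

Given the absence of any measured step of this kind, the expectation for compound 3 is a number close to that of compound 2, that is a step of a 1.2-fold lower number from compound 2 to compound 3 (0.08 log units; within the scatter) that may fall in either direction and need not reach beyond the scatter. The estimate for compound 3 in this assay is 18000 nM, with a range from 8000 nM to 45000 nM.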

Compound 3, half-maximal inhibitory concentration: 18500 nM
Compound 3: middle estimate off by 1.0-fold (0.01 log units), on the low side; low and high end bracket the measured number.
By their numbers in this assay, from the lowest: compounds 1, 3 and 2 (each within the scatter of the next).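

The change from 2-chlorophenyl to 2,3-dichlorophenyl gives the series its first reading between compounds that differ in one place: in this assay, the step of a 1.2-fold lower number from compound 2 to compound 3 (0.07 log units; within the scatter) stands for chloro in place of hydrogen on an aromatic carbon. At this position, ortho to a chloro group and meta to a large group, adding a second chloro therefore leaves the number within the scatter, something that compound 1 and compound 2 could not show, as they differ in more than one place. No measured data on the compounds bear on what lies behind this result.

Going by these compounds, this rests on a single pair on a single aromatic ring, so it remains open whether chloro at this position behaves the same way when the other aromatic ring carries the hydroxy and methoxy groups of compound 1 rather than the methoxy groups of compound 3. Also open, on these data alone, is whether a group of another kind at this position, such as an amine, a carboxylic acid or trifluoromethyl, would give a step beyond the scatter in this assay.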